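The source may hold more compounds than are shown below. What is called first, only, known or untested is meant among the compounds shown, and "the series" means these compounds.

In a functional assay on KBVIN cells (Homo sapiens) for antiproliferative activity, read by sulforhodamine B assay, with a stated time of 3 days (a lower number here means that less compound is needed, a higher number that more compound is needed for the effect), three compounds sharing one core differ only in the substituted phenyl group on that core. Compound 1 (`CCC1=C(O)c2c(oc(-c3ccc(OC)cc3)cc2=O)C(CC)(CC)C1=O`), with 4-methoxyphenyl, gives 0.68 uM. Compound 2 (`CCC1=C(O)c2c(oc(-c3ccccc3OC)cc2=O)C(CC)(CC)C1=O`), with 2-methoxyphenyl, gives 3.26 uM. Compound 3 (`CCC1=C(O)c2c(oc(-c3ccccc3F)cc2=O)C(CC)(CC)C1=O`), with 2-fluorophenyl, gives 3.93 uM. The two groups with a substituent numbered 2 cannot be told apart, as shown by a 1.2-fold higher number from compound 2 to compound 3 (0.08 log units; within the scatter). Leaving 4-methoxyphenyl makes a clearer difference, with a 4.8-fold higher number from compound 1 to compound 2 (0.68 log units; beyond the scatter) and a 5.8-fold higher number from compound 1 to compound 3 (0.76 log units; beyond the scatter). Compound 3 thus stands with the pair at the high end of these numbers, well away from the value of compound 1.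

Compound 4 (`CCC1=C(O)c2c(oc(-c3ccc(C)c(C)c3)cc2=O)C(CC)(CC)C1=O`) follows from compound 3 through one change: 3,4-dimethylphenyl in place of 2-fluorophenyl on an aromatic carbon. It has 3,4-dimethylphenyl in place of 2-fluorophenyl on an aromatic carbon. Among the measured compounds shown here, no measured compound carries methyl groups on this ring, so the comparison is indirect. The new group has a substituent numbered 4 and none numbered 2, as does compound 1 at 0.68 uM. Most of a 5.8-fold higher number from compound 1 to compound 3 (0.76 log units; beyond the scatter) is therefore expected to be recovered, though not all of it, given the different substituents. The expected result is a 3.0-fold lower number from compound 3 to compound 4 (0.48 log units; beyond the scatter), a modest move towards a lower number. Compound 4 is estimated at 1.3 uM, with an expected range from 0.5 uM to 3.5 uM.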

Compound 4, concentration for half-maximal effect: 0.71 uM
Compound 4: middle estimate off by 1.8-fold (0.26 log units), on the high side; measured number inside the range.
By their numbers in this assay, from the lowest: compounds 1 and 4 (each within the scatter of the next); then compounds 2 and 3 (each within the scatter of the next).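

In this assay, 3,4-dimethylphenyl in place of 2-fluorophenyl gives a 5.5-fold lower number from compound 3 to compound 4 (0.74 log units; beyond the scatter), and in place of 2-methoxyphenyl it gives a step of similar size, a 4.6-fold lower number from compound 2 to compound 4 (0.66 log units; beyond the scatter). Set against 4-methoxyphenyl, the same group cannot be told apart, with a 1.0-fold higher number from compound 1 to compound 4 (0.02 log units; within the scatter), so the low end of these numbers at this position is not confined to a ring carrying methoxy: a ring bearing only carbon substituents reaches it too, and among these four compounds, the two without a substituent numbered 2 both sit clearly apart from the two that have one, with no compound going against this. Nothing in the material shown explains why these groups differ in this way.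

The compounds shown leave open whether both methyl groups of 3,4-dimethylphenyl are needed or whether one alone would give the same reading, and how the unsubstituted phenyl ring would compare. They also leave open how far this tolerance extends, for instance to an amine, a carboxylic acid or a longer chain such as butyl on the same ring.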